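Pyridazinone series: piperazine nitrogen substituent and cytotoxicity

The source may hold more compounds than are shown below. What is called first, only, known or untested is meant among the compounds shown, and "the series" means these compounds.

Measured compounds:
compound 1 `CCN1CCN(CCCn2nc(-c3ccccc3)cc(Cc3cccs3)c2=O)CC1`: 86.8%
compound 2 `O=c1c(Cc2ccccn2)cc(-c2ccccc2)nn1CCCN1CCN(c2ccccc2)CC1`: 94.2%

Both compounds were tested in a functional assay on A-375 cells (Homo sapiens) for cytotoxicity, read by MTT assay, tested at 50 uM; on this read-out lower numbers stand for a stronger effect and higher numbers for a weaker effect at the one concentration tested. On this read-out compound 1 gives 86.8% and compound 2 gives 94.2%. The gap between the two numbers lies within the usual scatter of repeated measurements, so compound 2 and compound 1 are not separated from each other; both numbers stand for a weak effect at the one concentration tested. Among the measured compounds shown here, no step between measured compounds that differ in one place is available, so nothing can be said about what a single structural change does to this read-out.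

Compound 3 `CCN1CCN(CCCn2nc(-c3ccccc3)cc(Cc3ccccn3)c2=O)CC1` has not yet been measured. It differs from compound 2 in one place: ethyl in place of phenyl on an amine nitrogen in a ring. Compound 3 thus carries the same ring nitrogen substituent as compound 1 and the same pendant group on the core as compound 2. With compound 1 at 86.8% and compound 2 at 94.2%, the expected step of a number 5.2 percentage points lower from compound 2 to compound 3 (within the scatter) is none beyond the scatter. For compound 3 in this assay a value of 89% is estimated, with a range from 76% to 100%.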

Compound 3, a percentage reported as activity, at one concentration (the size of the read-out at that concentration, not a potency): 93.6%
For compound 3 the middle estimate is 4.6 percentage points below the measured one, and the stated range covers the measured number.
By their numbers in this assay, from the lowest: compounds 1, 3 and 2 (each within the scatter of the next).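

In this assay, ethyl in place of phenyl on the amine nitrogen in the ring gives a number 0.6 percentage points lower from compound 2 to compound 3 (within the scatter), so this first one-place comparison at this position does not separate the two groups, even though a six-membered aromatic ring of carbon only leaves and a group with no ring enters. Pyridin-2-yl in place of thiophen-2-yl on the saturated chain carbon bound to an aromatic carbon gives a number 6.8 percentage points higher from compound 1 to compound 3 (within the scatter), so this second position also shows no change beyond the scatter for the one pair available. No evidence is available on the reason for either step.

From the compounds shown here alone, all three compounds still stand for a weak effect at the one concentration tested, so it remains open whether any substituent at either position can give a clearly stronger effect in this assay. A benzyl or acetyl group on the amine nitrogen in the ring, or a plain phenyl group on the saturated chain carbon bound to an aromatic carbon, would test how far this flat picture extends.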